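The source may hold more compounds than are shown below. What is called first, only, known or untested is meant among the compounds shown, and "the series" means these compounds.

Three compounds have so far been measured in a functional assay on HT-29 cells (Homo sapiens) for inhibition, read by CCK-8 assay, with a stated time of 24 h; on this read-out higher numbers stand for weaker inhibition and lower numbers for stronger inhibition:

Compound 1 `O=C1Nc2ccccc2/C1=C/c1ccc(-c2cn(-c3ccc(Cl)cc3)nn2)cc1` gives 14000 nM.
Compound 2 `N#Cc1ccccc1-n1cc(-c2ccc(/C=C3\C(=O)Nc4ccccc43)cc2)nn1` gives 14400 nM.
Compound 3 `O=C1Nc2ccc(F)cc2C1=Cc1ccc(-c2cn(-c3ccc(Cl)cc3)nn2)cc1` gives 11200 nM.

Compound 1 and compound 2 differ in one place: 2-cyanophenyl in place of 4-chlorophenyl on an aromatic nitrogen. Between them the measurement moved by a 1.0-fold higher number from compound 1 to compound 2 (0.01 log units; within the scatter), so this change left the result essentially unchanged. Compound 3 shares the same arrangement of groups as compound 1 except in its core; how the two cores differ is not broken down here. The values of compound 3 and compound 2 lie within the usual scatter of each other, so nothing separates them on this read-out.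

Compound 4 `N#Cc1ccccc1-n1cc(-c2ccc(C=C3C(=O)Nc4ccc(F)cc43)cc2)nn1` has not yet been measured. It stands to compound 3 exactly as compound 2 stands to compound 1: 2-cyanophenyl in place of 4-chlorophenyl on an aromatic nitrogen, at the same place in the molecule in every respect. Because the earlier occurrence of this change gave a 1.0-fold higher number from compound 1 to compound 2 (0.01 log units; within the scatter), the same change on the core of compound 3 is expected to give a step of about a 1.0-fold higher number from compound 3 to compound 4 (0.01 log units; within the scatter). On that basis compound 4 is estimated to give roughly 11500 nM in this assay, with a likely range from 6000 nM to 22000 nM. For the measured compounds named here, this estimate rests on a single earlier step and on only three measured compounds, so it is held loosely until the measurement is in hand.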

Compound 4, half-maximal inhibitory concentration: > 13900 nM
Compound 4: only a limit was reported; the forecaster's own chance of this, stated with the estimate: 10%; at least 1.2-fold (0.08 log units) between middle value and limit.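

Compound 4 has a limit of the assay rather than a number: the limit of > 13900 nM in this assay, at which 1 of the 4 values shown sits. From the compounds shown here alone, on the core of compound 3, putting 2-cyanophenyl in place of 4-chlorophenyl gives an at least 1.2-fold higher number from compound 3 to compound 4 (0.09 log units; that floor lies within the scatter) in this assay, so only a floor for this step is known and its true size stays unknown. The step therefore does not show that the change carries over from one core to another with the same size, and it does not show that the two cores respond differently either: the same change on two cores in this assay, a 1.0-fold higher number (0.01 log units; within the scatter) from compound 1 to compound 2 and an at least 1.2-fold higher number (0.09 log units; that floor lies within the scatter) from compound 3 to compound 4; the limit leaves it open whether they differ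

The four compounds shown cover only two groups on the aromatic nitrogen and two cores, so they leave open whether any change at that place can move the result in this assay well beyond the usual scatter of repeated measurements. A saturated group on that nitrogen, such as a short alkyl chain, or an aryl ring carrying an amine or a carboxylic acid, lies outside this set, and how such groups would read on either core remains an open question.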